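A few compounds are considered here, and "the series" means these few. Any claim that something is new, unique, unknown or untested is made for them only; others in the source may bear on it.

Measured in an ADME assay on a cell-free system (plasma, Homo sapiens) for protein binding:
- compound 1 `Cc1ccc(C2CCN(Cc3cc(C(=O)O)c(=O)n4ccccc34)CC2)cc1`: 91%
- compound 2 `O=C(O)c1cc(CN2CCC(n3cnc4ccccc43)CC2)c2ccccn2c1=O`: 79%

Of the two, the higher unbound fraction belongs to compound 2, which gives 79%. Compound 3 `O=C(O)c1cc(CN2CCC(c3nc4ccccc4[nH]3)CC2)c2ccccn2c1=O` keeps the same atoms as compound 2, joined differently: 1H-benzimidazol-2-yl in place of 1H-benzimidazol-1-yl on a saturated ring carbon. For the measured compounds named here, the only measured step, a 2.3-fold higher unbound fraction from compound 1 to compound 2 (0.37 log units; beyond the scatter), is modest and bears only indirectly, as it replaced 4-methylphenyl, a different group. Going by the values given here, no measured step covers this exchange of 1H-benzimidazol-1-yl for 1H-benzimidazol-2-yl, so no step beyond the scatter is expected in this assay, and the direction stays open. The expected step is a 1.1-fold lower unbound fraction from compound 2 to compound 3 (0.02 log units; within the scatter). The estimate for compound 3 is 80%, with a range of 62% to 91%.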

Compound 3, plasma protein binding in the plasma assay: 82%
Compound 3: the middle estimate sits 1.1-fold (0.05 log units) (unbound fraction) above what was measured; low and high end bracket the measured number.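

In the plasma assay, the change at this saturated ring carbon from 1H-benzimidazol-1-yl to 1H-benzimidazol-2-yl, same atoms joined differently, gives a 1.2-fold lower unbound fraction from compound 2 to compound 3 (0.07 log units; within the scatter), so the point of attachment is not resolved on this read-out. Against 4-methylphenyl, the new group gives a 2.0-fold higher unbound fraction from compound 1 to compound 3 (0.30 log units; within the scatter), whereas a 2.3-fold higher unbound fraction from compound 1 to compound 2 (0.37 log units; beyond the scatter) was printed beyond the scatter. No evidence on the origin of these differences is available.

In a physicochemical assay for lipophilicity (on this read-out higher numbers stand for higher lipophilicity and lower numbers for lower lipophilicity), compound 2 gives 0.92 and compound 3 gives "not determined" (no result reported), so that comparison cannot be read. Going by these compounds, whether an amine or a carboxylic acid at this ring carbon would shift the unbound fraction beyond the scatter remains open.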